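Azido to Hydroxy on the Thymidine Monophosphate Scaffold

This account rests on a few compounds, and the source may have more. Where it says the series, first, only, none or still open, it means among the compounds named here.

Compound 1 `Cc1cn([C@H]2C[C@H](CN=[N+]=[N-])[C@@H](COP(=O)(O)O)O2)c(=O)[nH]c1=O` is the more potent of the two compounds measured in an assay on isolated protein for inhibition of thymidine kinase, cytosolic (Homo sapiens) (on this read-out higher numbers stand for weaker inhibition and lower numbers for stronger inhibition), where compound 1 gives 32000 nM. Compound 2 `Cc1cn([C@H]2C[C@H](CF)[C@@H](CO)O2)c(=O)[nH]c1=O`, which lacks the phosphate, is far weaker: in this assay compound 2 gives 970000 nM, a gap beyond the usual scatter. Compound 3 `Cc1cn([C@H]2C[C@H](CO)[C@@H](COP(=O)(O)O)O2)c(=O)[nH]c1=O` keeps the phosphate of compound 1 and differs only by hydroxy in place of azido on a saturated chain carbon bound to a saturated ring carbon. Among the measured compounds shown here, no measured pair shows this exact change, so only a modest step is expected, from compound 1 to compound 3 a 1.3-fold higher number from compound 1 to compound 3 (0.10 log units; within the scatter), likely within the scatter. Compound 3 is therefore estimated at 40000 nM, with a range from 8000 nM to 200000 nM.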

Compound 3, inhibition constant: 43500 nM
Compound 3: the middle estimate sits 1.1-fold (0.04 log units) below what was measured; measured number inside the range.
By their numbers in this assay, from the lowest: compounds 1 and 3 (each within the scatter of the next); then compound 2.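

Hydroxy in place of azido on a saturated chain carbon bound to a saturated ring carbon gives a 1.4-fold higher number from compound 1 to compound 3 (0.13 log units; within the scatter) in this assay and so leaves the two compounds indistinguishable. With the phosphate kept, this position therefore accepts hydroxy as well as azido, although three heavy atoms give way to one. Nothing available explains why the two groups read alike. From the compounds shown here alone, whether an amine, a carboxylic acid or a longer chain at this place would also read alike remains open. So does whether this swap would read the same without the phosphate.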